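This account rests on a few compounds, and the source may have more. Where it says the series, first, only, none or still open, it means among the compounds named here.

Of the compounds shown here, two have been tested so far in a functional assay on HepG2 cells (Homo sapiens) for antiproliferative activity, read by MTT assay, with a stated time of 72 h; a lower number here means a stronger inhibitor, a higher number a weaker inhibitor. Compound 1 `Cc1ccc(Oc2c(/C=N\CCCCCOc3cc4oc(=O)cc(C)c4cc3Cl)c(C)nn2C)cc1` gives 10300 nM. Compound 2 `Cc1nn(C)c(Oc2ccccc2F)c1/C=N\CCCCCCOc1cc2oc(=O)cc(C)c2cc1Cl` gives only > 25000 nM, which is a limit rather than a measured number. That reading is the limit of > 25000 nM in this assay, at which 1 of the 2 values shown sits. Compound 1 and compound 2 differ in more than one place, so their two values stand side by side and no single change can be tied to the gap between them.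

Compound 3 `Cc1nn(C)c(Oc2cccc(F)c2)c1/C=N\CCCCCCOc1cc2oc(=O)cc(C)c2cc1Cl` differs from compound 2 in one place only: 3-fluorophenyl in place of 2-fluorophenyl on an oxygen on an aromatic ring. The shared core and the rest of the molecule are unchanged. For the measured compounds named here, no measured pair shows what this change does in this assay, and the starting point is itself a limit, so there is little to build on. The expected step is a number no higher from compound 2 to compound 3 (the limit leaves the size open), that is, none beyond the scatter, with a fair chance that compound 3 again returns only a limit. On that basis compound 3 is estimated at 25000 nM in this assay, with a range from 9000 nM to 70000 nM.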

Compound 3, half-maximal inhibitory concentration: > 25000 nM
Compound 3 gave a limit, no number; the forecaster's own chance of this, stated with the estimate: 60%; the middle value lies on the limit itself.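

Compound 2 and compound 3 each return only a limit in this assay, so no step can be read between them: the limit of > 25000 nM in this assay, at which 2 of the 3 values shown sit.

Still open, as far as these compounds go, is whether 3-fluorophenyl in place of 2-fluorophenyl changes the reading in this assay at all, and how far beyond the limit either compound lies.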